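The source may hold more compounds than are shown below. What is called first, only, known or untested is meant among the compounds shown, and "the series" means these compounds.

Measured in a functional assay on DU-145 cells (Homo sapiens) for antiproliferative activity, read by sulforhodamine B assay, with a stated time of 3 days; on this read-out higher numbers stand for weaker inhibition of growth and lower numbers for stronger inhibition of growth:
- compound 1 `O=C(Nc1ccc(C(F)(F)F)cc1)c1cccc(Nc2ncc(F)c(Nc3ccc(F)cc3)n2)c1` | > 10000 nM (a limit of the assay, not a number)
- compound 2 `O=C(Nc1cccc(Nc2ncc(F)c(Nc3ccc(F)cc3)n2)c1)c1cccc([N+](=O)[O-])c1` | 12600 nM

Compound 1 gives only a limit, > 10000 nM. Within the data shown here, that leaves compound 2, at 12600 nM, as the only compound with an actual number, so the two cannot be ranked against each other.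

Compound 3 `CN(C)CC(=O)Nc1cccc(Nc2ncc(F)c(Nc3ccc(F)cc3)n2)c1` keeps the shared core and carries (dimethylamino)methyl in place of 3-nitrophenyl on a carbonyl carbon. Among the measured compounds shown here, no measured step shows what this kind of swap does, so the expectation starts from compound 2 at 12600 nM and favours neither direction. The estimated change, a 1.3-fold lower number from compound 2 to compound 3 (0.10 log units; within the scatter), stays within the usual scatter, although the uncertainty is wide. For compound 3 the expected value is 10000 nM, with an estimated range of 3000 nM to 30000 nM.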

Compound 3, concentration for 50% growth inhibition: 1210 nM
The estimate for compound 3 lay 8.3-fold (0.92 log units) above the measured number; the whole stated range lies above it.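

Among these compounds, the group on the carbonyl carbon turns out to matter for growth inhibition, something the earlier compounds could not show, since they offered no step at all. In this assay, the swap of 3-nitrophenyl for (dimethylamino)methyl gives a 10-fold lower number from compound 2 to compound 3 (1.02 log units; beyond the scatter), a change beyond the usual scatter and towards stronger inhibition. So an aromatic ring on this carbonyl carbon is not needed for activity in these cells, and an open chain carrying an amine is tolerated and does better here.

This single step removes the ring and adds the amine at once, so it cannot say which of the two matters; a plain methyl, or a longer chain ending in the same dimethylamino group, on this carbonyl carbon would help to separate them. Compound 1 still offers no number for comparison, only a limit of the assay: the limit of > 10000 nM in this assay, at which 1 of the 3 values shown sits.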